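The source may report more compounds than this note shows. Statements on the series, on what has been measured and on what is new or still open speak of the compounds shown alone.

Within the data shown here, compound 3 `Cc1cc(-c2ccccn2)nn1S(=O)(=O)Oc1ccccc1` gives 15% in a functional assay on the whole organism for inhibition, with Mus musculus as the target, in the writhing test, with stated times of 3 days and 20 min, at a dose of 30 mg/kg by the oral route (a lower number here means less inhibition, a higher number more inhibition at the dose given (going by the name of the read-out)), the lowest of the three numbers measured so far. Compound 1 `Cc1ccc(-c2cc(C)n(S(=O)(=O)Oc3ccccc3)n2)cc1` gives 50.7% and compound 2 `Cc1cc(-c2cccc(Cl)c2)nn1S(=O)(=O)Oc1ccccc1` gives 18.9%; the step of a number 35.7 percentage points lower from compound 1 to compound 3 (beyond the scatter) is large, whereas the step of a number 3.9 percentage points lower from compound 2 to compound 3 (within the scatter) lies within the scatter. Compound 4 `Cc1cc(-c2ccco2)nn1S(=O)(=O)Oc1ccccc1` differs from compound 3 in one place: furan-2-yl in place of pyridin-2-yl on an aromatic carbon. Exchanging one aromatic ring for another at this position has produced both a large step and a negligible one, so the outcome for compound 4 is uncertain. Since the step of a number 3.9 percentage points lower from compound 2 to compound 3 (within the scatter) stayed within the scatter, the step of a number 3 percentage points higher from compound 3 to compound 4 (within the scatter) is expected to stay within the scatter as well. Compound 4 is therefore estimated at 18%, with a range from 5% to 40%.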

Compound 4, a percentage reported as inhibition, in the whole organism at one dose (the size of the read-out at that dose, not a potency): 42.5%
For compound 4 the middle estimate is 24.5 percentage points below the measured one; the whole stated range lies below it.
By their numbers in this assay, from the lowest: compounds 3 and 2 (each within the scatter of the next); then compounds 4 and 1 (each within the scatter of the next).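

In this assay this position proves able to recover from the low numbers: furan-2-yl gives a number 27.5 percentage points higher from compound 3 to compound 4 (beyond the scatter) and a number 23.6 percentage points higher from compound 2 to compound 4 (beyond the scatter) while it gives a number 8.2 percentage points lower from compound 1 to compound 4 (within the scatter). A heteroaromatic ring here is thus not low as such, since furan-2-yl and pyridin-2-yl each carry one hetero atom and one acceptor yet stand apart, with furan-2-yl level with 4-methylphenyl. Nothing available explains this difference between the rings. Open, from the compounds shown here alone, is how thiophen-2-yl would compare with furan-2-yl. Also open, going by these compounds, is whether an open-chain group such as a butyl chain or an aminomethyl group would serve at this position.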